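The source may report more compounds than this note shows. Statements on the series, on what has been measured and on what is new or still open speak of the compounds shown alone.

Within the data shown here, compound 3 `CCCCN(c1nc2c(-c3ccccn3)cccc2o1)[C@H](C)c1ccc(-c2ccccc2-c2nnn[nH]2)cc1` gives 110 nM in a functional assay on CAL1 cells for inhibition of chemerin-like receptor 1 (Homo sapiens), with a stated time of 45 min (a higher number here means a weaker inhibitor, a lower number a stronger inhibitor), the highest of the three numbers measured so far. Compound 1 `CCCCN(c1nc2c(CO)cccc2o1)[C@H](C)c1ccc(-c2ccccc2-c2nnn[nH]2)cc1` gives 24 nM in this assay, and compound 2 `CCCCN(c1nc2c(C(=O)NS(C)(=O)=O)cccc2o1)[C@H](C)c1ccc(-c2ccccc2-c2nnn[nH]2)cc1` gives 14 nM. Both measured steps that lead into compound 3 run upward, a 4.6-fold higher number from compound 1 to compound 3 (0.66 log units; beyond the scatter) and a 7.9-fold higher number from compound 2 to compound 3 (0.90 log units; beyond the scatter), whereas the step of a 1.7-fold lower number from compound 1 to compound 2 (0.23 log units; within the scatter) stays within the scatter. Compound 4 `CCCCN(c1nc2c(C(=O)N(C)C)cccc2o1)[C@H](C)c1ccc(-c2ccccc2-c2nnn[nH]2)cc1` carries dimethylcarbamoyl in place of pyridin-2-yl on an aromatic carbon. The pyridin-2-yl, which in both measured steps into compound 3 came with the higher number, is removed, and a dimethylcarbamoyl takes its place, a group that shares the carbamoyl part of the (methylsulfonyl)carbamoyl of compound 2. Among the measured compounds shown here, no measured step concerns dimethylcarbamoyl itself, so the expectation rests on the two steps into compound 3, both modest and beyond the scatter. A downward step in this assay of about the size of the two steps into compound 3 is therefore expected, a 4.4-fold lower number from compound 3 to compound 4 (0.64 log units; beyond the scatter). For compound 4 the estimated value in this assay is 25 nM, with a range from 10 nM to 70 nM.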

Compound 4, half-maximal inhibitory concentration: 13 nM
Estimate against measurement, compound 4: 1.9-fold (0.28 log units) above, and the stated range covers the measured number.
By their numbers in this assay, from the lowest: compounds 4, 2 and 1 (each within the scatter of the next); then compound 3.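

In this assay the step of an 8.5-fold lower number from compound 3 to compound 4 (0.93 log units; beyond the scatter) shows that a group with no ring, dimethylcarbamoyl, can replace pyridin-2-yl on this aromatic carbon and leave compound 3 alone at the high end. The steps of a 1.1-fold lower number from compound 2 to compound 4 (0.03 log units; within the scatter) and a 1.8-fold lower number from compound 1 to compound 4 (0.27 log units; within the scatter) cannot separate dimethylcarbamoyl from (methylsulfonyl)carbamoyl or hydroxymethyl at this position. Compound 4 also shows that methanesulfonamido on the carbonyl carbon is not required for a number of this size, since dimethylamino serves as well.

Among these compounds, with pyridin-2-yl the only ring-bearing group here, the compounds leave open whether a phenyl ring, a morpholine amide or a carboxylic acid on this carbon would fall with compound 3 or with the other three. Nothing in hand accounts for the gap between pyridin-2-yl and the other groups.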